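The source may report more compounds than this note shows. Statements on the series, on what has been measured and on what is new or still open speak of the compounds shown alone.

Three compounds built on one shared core have been examined in a functional assay on the whole organism (artery, strain albino) with Rattus norvegicus as the target, with a stated time of 60 min, at a dose of 10 mg/kg by the oral route; on this read-out lower numbers stand for less inhibition and higher numbers for more inhibition at the one dose given (going by the name of the read-out). Compound 1 `CC1=C(C(=O)Nc2ccc(Br)cc2)C(c2ccc(Cl)cc2Cl)N=C(SCc2cccc(Cl)c2)N1` gives 6.2%. Compound 2 `CC1=C(C(=O)Nc2ccc(Br)cc2)C(c2ccc(Cl)cc2Cl)N=C(SCc2ccc(Cl)cc2)N1` carries 4-chlorophenyl in place of 3-chlorophenyl on a saturated chain carbon bound to a sulfur, and in this assay compound 2 gives 11.8%, a step of a number 5.6 percentage points higher from compound 1 to compound 2 (within the scatter). Compound 3 `COc1ccc(C2N=C(SCc3cccc(Cl)c3)NC(C)=C2C(=O)Nc2ccc(Br)cc2)cc1` differs from compound 1 by 4-methoxyphenyl in place of 2,4-dichlorophenyl on a saturated ring carbon, and in this assay compound 3 gives 15.4%, a step of a number 9.2 percentage points higher from compound 1 to compound 3 (within the scatter). Compound 4 `COc1ccc(C2N=C(SCc3ccc(Cl)cc3)NC(C)=C2C(=O)Nc2ccc(Br)cc2)cc1` has not yet been measured; it differs from compound 3 by 4-chlorophenyl in place of 3-chlorophenyl on a saturated chain carbon bound to a sulfur, the same change that separates compound 1 from compound 2, made at the same place. Because the earlier step was a number 5.6 percentage points higher from compound 1 to compound 2 (within the scatter), the step from compound 3 to compound 4 is expected to be a number 3.6 percentage points higher from compound 3 to compound 4 (within the scatter). Compound 4 is therefore estimated to give 19% in this assay, expected to fall between 8% and 32%.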

Compound 4, a percentage reported as inhibition, in the whole organism at one dose (the size of the read-out at that dose, not a potency): 12.3%
Compound 4: middle estimate off by 6.7 percentage points, on the high side; measured number inside the range.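

In this assay, 4-chlorophenyl in place of 3-chlorophenyl on a saturated chain carbon bound to a sulfur gives a number 3.1 percentage points lower from compound 3 to compound 4 (within the scatter), and the two cores can be set side by side for this change: the same change on two cores in this assay, a number 5.6 percentage points higher (within the scatter) from compound 1 to compound 2 and a number 3.1 percentage points lower (within the scatter) from compound 3 to compound 4, 8.7 percentage points apart, within the scatter of two such steps. 4-methoxyphenyl in place of 2,4-dichlorophenyl on a saturated ring carbon gives a number 0.5 percentage points higher from compound 2 to compound 4 (within the scatter), and the comparison reads the same way: the same change on two cores in this assay, a number 9.2 percentage points higher (within the scatter) from compound 1 to compound 3 and a number 0.5 percentage points higher (within the scatter) from compound 2 to compound 4, 8.7 percentage points apart, within the scatter of two such steps. Every step among these compounds stays within the scatter, so the data show no difference between the cores but do not show that either change has a real effect that carries over.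

On these data alone, it remains open whether an amine or a carboxylic acid in place of the chlorine on the benzyl group would give a larger step. The same is true of a longer chain in place of the 4-chlorobenzyl group.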